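The compounds below may be only part of what the source reports. "The series", "measured", "known", "first", "only" and "open" are said of these compounds alone.

Measured so far: compound 1 `Cc1ccc(C)n1-c1ccc(C(=O)N/N=C/c2ccc(N(C)C)cc2)cc1`, with "not determined" (no result reported) in an ADME assay on Vero cells (Chlorocebus sabaeus) for cytotoxicity, read by MTT assay, with a stated time of 72 h; a higher number here means a weaker inhibitor, a lower number a stronger inhibitor; compound 2 `O=C(NNC(=O)c1ccccc1[N+](=O)[O-])c1ccc(-n2cccc2)cc1`, giving 182000 nM in this assay.

In this assay, among the compounds with values here, compound 2 carries the only number recorded, since compound 1 has no result there. Compound 3 `O=C(NNC(=O)c1ccccc1Br)c1ccc(-n2cccc2)cc1` differs from compound 2 in a single place: bromo in place of nitro on an aromatic carbon. Within the data shown here, no pair of measured compounds shows what this change does, so nothing measured speaks for a shift in either direction. The step expected in this assay is a 1.1-fold lower number from compound 2 to compound 3 (0.06 log units; within the scatter), that is, none beyond the usual scatter. Compound 3 is accordingly estimated at 160000 nM, with a range from 60000 nM to 420000 nM.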

Compound 3, half-maximal inhibitory concentration: 198000 nM
Compound 3: the middle estimate sits 1.2-fold (0.09 log units) below what was measured; the measured number falls inside the stated range.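

In this assay, within the data shown here, the first measured pair for this change gives a 1.1-fold higher number from compound 2 to compound 3 (0.04 log units; within the scatter) when bromo takes the place of nitro on an aromatic carbon ortho to a large group. At this position, then, two different groups leave the number within the scatter, even though bromo brings no hydrogen-bond acceptors and nitro brings some. Nothing measured accounts for this result. The compounds shown leave open whether an amine or a carboxylic acid at this position would also stay within the scatter. With only bromo and nitro compared here, they do not show whether any group on this carbon can move the number beyond it.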